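Swapping Trifluoromethyl for Chloro on a Urea Quinolone

The compounds below may be only part of what the source reports. "The series", "measured", "known", "first", "only" and "open" are said of these compounds alone.

Measured compounds:
Compound 1 (`COc1cc(OC)c2c(=O)cc(C(=O)Nc3cccc(-n4ccnc4)c3)[nH]c2c1`): > 16300 nM
Compound 2 (`COC(=O)c1cc(=O)c2cc(NC(=O)Nc3ccc(Cl)c(C(F)(F)F)c3)ccc2[nH]1`): > 6350 nM

Of the compounds shown here, two have been measured in a functional assay on KOPN-8 cells (Homo sapiens) for antiproliferative activity, with a stated time of 72 h; on this read-out higher numbers stand for an effect only at larger amounts of compound and lower numbers for an effect already at smaller amounts. Compound 1 (`COc1cc(OC)c2c(=O)cc(C(=O)Nc3cccc(-n4ccnc4)c3)[nH]c2c1`) gives only a limit there, > 16300 nM, so no number is known for it. Compound 2 (`COC(=O)c1cc(=O)c2cc(NC(=O)Nc3ccc(Cl)c(C(F)(F)F)c3)ccc2[nH]1`) likewise gives only a limit, > 6350 nM, which is where it stands among the values shown: the limit of > 6350 nM in this assay, at which 1 of the 2 values shown sits. Among the compounds with values here, neither compound shows an effect within the tested range, and no step between measured compounds is known.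

Compound 3 (`COC(=O)c1cc(=O)c2cc(NC(=O)Nc3ccc(Cl)c(Cl)c3)ccc2[nH]1`) differs from compound 2 in one place: chloro in place of trifluoromethyl on an aromatic carbon. Both groups are small and neutral, and compound 2 itself shows no measurable effect, so no step beyond the usual scatter in this assay is expected in either direction. The step from compound 2 to compound 3 is estimated as a step that the limit leaves unreadable from compound 2 to compound 3. For compound 3 the estimated value in this assay is 15000 nM, within a range from 4000 nM to 60000 nM, with a high chance that the assay again reports only a limit.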

Compound 3, half-maximal effective concentration: > 6350 nM
Compound 3: no number, only a limit; the forecaster's own chance of this, stated with the estimate: 75%; the middle value does not contradict the limit.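

No step can be read from compound 2 to compound 3: in this assay each of the two gives only a limit, not a number. The compounds shown leave open whether chloro in place of trifluoromethyl changes the effect on these cells at all, and in which direction.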